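Cyclopropane amides on colon carcinoma cells: ester to alcohol

The compounds below may be only part of what the source reports. "The series", "measured", "known", "first", "only" and "open" are said of these compounds alone.

Measured so far in a functional assay on SW480 cells (Homo sapiens) for cytotoxicity, read by MTT assay, with a stated time of 48 h; on this read-out higher numbers stand for weaker inhibition and lower numbers for stronger inhibition:
compound 1 `CCOC(=O)[C@@]1(C(=O)NCc2ccc(C)cc2)C[C@H]1c1cc(OC)c(OC)c(OC)c1`: > 100000 nM
compound 2 `COc1cc([C@@H]2C[C@@]2(CO)C(=O)NCc2ccc(C)cc2)cc(OC)c1OC`: 76300 nM
compound 3 `CCOC(=O)[C@@]1(C(=O)Nc2ccccc2Cl)C[C@H]1c1cc(OC)c(OC)c(OC)c1`: 30100 nM

The value of compound 1 is a limit of this assay, not a number; it sits at the limit of > 100000 nM in this assay, at which 1 of the 3 values shown sits. From compound 1 the change hydroxymethyl in place of ethoxycarbonyl on a saturated ring carbon gives an at least 1.3-fold lower number from compound 1 to compound 2 (0.11 log units; that floor lies within the scatter), a step whose floor lies within the scatter. The change 2-chlorophenyl in place of 4-methylbenzyl on an amide-type nitrogen gives an at least 3.3-fold lower number from compound 1 to compound 3 (0.52 log units; beyond the scatter). Compound 4 `COc1cc([C@@H]2C[C@@]2(CO)C(=O)Nc2ccccc2Cl)cc(OC)c1OC` is not yet measured; it differs from compound 3 by hydroxymethyl in place of ethoxycarbonyl on a saturated ring carbon, the same change as from compound 1 to compound 2, with the same surroundings. The cores of compound 3 and compound 4 differ from those of compound 1 and compound 2 by the amide substituent already described. The expected step is a 1.2-fold lower number from compound 3 to compound 4 (0.08 log units; within the scatter), resting on the measured step from compound 1 to compound 2 and on compound 3 giving 30100 nM. Compound 4 is estimated at 25000 nM, between 8000 nM and 80000 nM.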

Compound 4, half-maximal inhibitory concentration: 10700 nM
Compound 4: middle estimate off by 2.3-fold (0.37 log units), on the high side; the range from low to high includes it.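

In this assay, hydroxymethyl in place of ethoxycarbonyl gives a 2.8-fold lower number from compound 3 to compound 4 (0.45 log units; beyond the scatter), and 2-chlorophenyl in place of 4-methylbenzyl gives a 7.1-fold lower number from compound 2 to compound 4 (0.85 log units; beyond the scatter). The 2-chlorophenyl change lowers the number beyond the scatter on both cores, so its direction carries over, but its size may or may not: the same change on two cores in this assay, an at least 3.3-fold lower number (0.52 log units; beyond the scatter) from compound 1 to compound 3 and a 7.1-fold lower number (0.85 log units; beyond the scatter) from compound 2 to compound 4; the limit leaves it open whether they differ. The hydroxymethyl change is beyond the scatter only on the core of compound 3, so neither its direction nor its size is shown to carry over from the core of compound 1: the same change on two cores in this assay, an at least 1.3-fold lower number (0.11 log units; that floor lies within the scatter) from compound 1 to compound 2 and a 2.8-fold lower number (0.45 log units; beyond the scatter) from compound 3 to compound 4; the limit leaves it open whether they differ.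

Still open, as far as these compounds go, is how a carboxylic acid or an aminomethyl group would compare with hydroxymethyl on the same saturated ring carbon. Also open, from the compounds shown here alone, is whether a 2-fluorophenyl or an unsubstituted phenyl group on the amide nitrogen would behave like 2-chlorophenyl.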